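Chloro to methoxy on the aryl ring of compound 3

This account rests on a few compounds, and the source may have more. Where it says the series, first, only, none or still open, it means among the compounds named here.

Measured compounds:
compound 1 `Cc1ccc(C2=Nn3c(nnc3C(C)c3ccc(-c4ccccc4)c(F)c3)SC2)cc1` gives 5000 nM in a functional assay on MCF7 cells (Homo sapiens) for inhibition, read by sulforhodamine B assay, with a stated time of 72 h; on this read-out higher numbers stand for weaker inhibition and lower numbers for stronger inhibition
compound 2 `CC(C)Cc1ccc(C(C)c2nnc3n2N=C(c2ccc(Br)cc2)CS3)cc1` gives 9400 nM in this assay
compound 3 `CC(C)Cc1ccc(C(C)c2nnc3n2N=C(c2ccc(Cl)cc2)CS3)cc1` gives 8800 nM in this assay

Compound 3 sits among the three numbers with compound 2 nearest and compound 1 furthest, and both of those gaps lie within the scatter, so none of the three is separated from the others.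

Among the measured compounds shown here, the only step available between measured compounds is a 1.1-fold lower number from compound 2 to compound 3 (0.03 log units; within the scatter), a change of one halogen for another on the aromatic carbon; it does not bear directly on the change considered here. Compound 4 `COc1ccc(C2=Nn3c(nnc3C(C)c3ccc(CC(C)C)cc3)SC2)cc1` has not been measured in this assay. It differs from compound 3 by methoxy in place of chloro on an aromatic carbon. For the measured compounds named here, no measured pair shows chloro exchanged for methoxy, so the expectation rests on the general picture that the three measured numbers lie close together despite differing aryl substituents. The step of a 1.1-fold lower number from compound 3 to compound 4 (0.04 log units; within the scatter) is therefore expected to stay within the scatter, with no clear direction. Compound 4 is estimated at 8000 nM, with a range from 3000 nM to 25000 nM.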

Compound 4, half-maximal inhibitory concentration: 5200 nM
Beside the measured number, compound 4's estimate is 1.5-fold (0.19 log units) above it; low and high end bracket the measured number.
By their numbers in this assay, from the lowest: compounds 1, 4, 3 and 2 (each within the scatter of the next).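

In this assay, the change from 4-chlorophenyl to 4-methoxyphenyl gives a 1.7-fold lower number from compound 3 to compound 4 (0.23 log units; within the scatter) and the exchange of bromo for methoxy on the same aromatic carbon gives a 1.8-fold lower number from compound 2 to compound 4 (0.26 log units; within the scatter) in the same read-out. The earlier step at this position involved only two halogens; here a methoxy, with two heavy atoms and one hydrogen-bond acceptor, takes the place of a single halogen atom with no acceptor, and the read-out still does not separate compound 4 from compound 2 or compound 3. No other measurement shown here bears on this result.

The compounds shown leave open whether an amine, a carboxylic acid or a longer chain such as ethoxy on this aromatic carbon would also stay within the scatter of these numbers. They also leave open whether the exchange of chloro for methoxy would read the same in a compound that otherwise carries the groups of compound 1.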